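A few compounds are considered here, and "the series" means these few. Any claim that something is new, unique, unknown or untested is made for them only; others in the source may bear on it.

Compound 1, `C#CCSc1nnc(-c2cc(OC)c(OC)c(OC)c2)n1N1C(=O)c2ccccc2C1=O`: in a functional assay on HepG2 cells (Homo sapiens) for cytotoxicity, read by MTT assay, with a stated time of 48 h (on this read-out higher numbers stand for weaker inhibition and lower numbers for stronger inhibition), compound 1 gives > 200000 nM, which is a limit of the assay and not a number.
Compound 2, `COc1cc(-c2nnc(SCc3ccccc3)n2N2C(=O)c3ccccc3C2=O)cc(OC)c1OC`: in this assay compound 2 gives > 200000 nM, again a limit.
Compound 3, `COc1cc(-c2nnc(SCC(=O)c3ccccc3C)n2N2C(=O)c3ccccc3C2=O)cc(OC)c1OC`: in this assay compound 3 gives > 200000 nM, likewise a limit.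

All three measured compounds share the same core and differ only in the group carried on the saturated chain carbon bound to the sulfur. Because every one of them sits at the limit of > 200000 nM in this assay, at which 3 of the 3 values shown sit, none of the steps between them can be sized: a step that the two limits leave unreadable from compound 1 to compound 2, a step that the two limits leave unreadable from compound 1 to compound 3 and a step that the two limits leave unreadable from compound 2 to compound 3 are all unreadable. Compound 3 therefore stands only at a limit, with no numeric value to place it against the other two.

Compound 4, `COc1cc(-c2nnc(SCC(=O)c3ccc(Br)cc3)n2N2C(=O)c3ccccc3C2=O)cc(OC)c1OC`, keeps the whole of compound 3 apart from one exchange: 4-bromophenyl in place of 2-methylphenyl on a carbonyl carbon. Going by the values given here, no measured step bears directly on this exchange, since none of the three compounds carries a halogen on that ring and no step among them could be read at all. With every comparable compound returning only a limit, the expectation for the step from compound 3 to compound 4 is a step that the limit leaves unreadable from compound 3 to compound 4, meaning no movement beyond the scatter. On that basis compound 4 is estimated to give 300000 nM in this assay, within a range from 150000 nM to 1000000 nM, with a strong chance that only a limit is reported again.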

Compound 4, half-maximal inhibitory concentration: 27700 nM
The estimate for compound 4 lay 11-fold (1.03 log units) above the measured number; the whole stated range lies above it.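

In this assay, 4-bromophenyl in place of 2-methylphenyl on a carbonyl carbon gives an at least 7.2-fold lower number from compound 3 to compound 4 (0.85 log units; beyond the scatter), the first sign in the series that the ring on this carbonyl can move the read-out beyond the scatter. The same gain appears against the two other groups on the saturated chain carbon bound to a sulfur: (4-bromophenyl)carbonyl in place of phenyl gives an at least 7.2-fold lower number from compound 2 to compound 4 (0.85 log units; beyond the scatter), and in place of ethynyl it gives an at least 7.2-fold lower number from compound 1 to compound 4 (0.85 log units; beyond the scatter). These three steps give only a lower bound on their size, and the steps among the first three compounds still cannot be read, since every compound but one stands at a limit: the limit of > 200000 nM in this assay, at which 3 of the 4 values shown sit.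

The exchange removes the methyl and brings in the bromine at once, so the compounds shown cannot separate the effect of losing one from that of gaining the other, nor show whether the bromine's place on the ring matters. Nor do they show how the read-out responds to an unsubstituted phenyl on the carbonyl carbon, or to a chlorine or a methoxy group in place of the bromine.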